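Working notes on the step from compound 3 to compound 4

A few compounds are considered here, and "the series" means these few. Any claim that something is new, unique, unknown or untested is made for them only; others in the source may bear on it.

Measured so far in a functional assay on NCI-H460 cells (Homo sapiens) for inhibition, read by MTT assay, with a stated time of 72 h; on this read-out lower numbers stand for stronger inhibition and higher numbers for weaker inhibition:
- compound 1 `COc1cc(NC(C)CCCNC(=O)Nc2ccc(F)cc2)c2ncccc2c1` gives 26000 nM
- compound 2 `COc1cc(NC(C)CCCNC(=O)Nc2ccc(O)cc2)c2ncccc2c1` gives 34000 nM
- compound 3 `COc1cc(NC(C)CCCNC(=O)NNC(=O)Nc2ccc(O)cc2)c2ncccc2c1` gives > 100000 nM, which is a limit of the assay and not a number.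

Compound 3 therefore stands at the weak end of the three, with only a limit of > 100000 nM in this assay, at which 1 of the 3 values shown sits, to mark its place. The steps leading to it, an at least 3.8-fold higher number from compound 1 to compound 3 (0.58 log units; beyond the scatter) and an at least 2.9-fold higher number from compound 2 to compound 3 (0.46 log units; beyond the scatter), are both beyond the scatter, whereas a 1.3-fold higher number from compound 1 to compound 2 (0.12 log units; within the scatter) is not.

Compound 4 `COc1cc(NC(C)CCCNC(=O)Nc2cccc(O)c2)c2ncccc2c1` is the next compound, differing from compound 3 by 3-hydroxyphenyl in place of ((4-hydroxyphenyl)carbamoyl)amino on an amide-type nitrogen. This largely reverses the change seen in the two steps into compound 3, so the expectation is a lower number, at least modest in size, back toward the range of compound 1 and compound 2. Compound 2 and compound 4 differ only in the hydroxyphenyl group, and no step between them is shown, so the value of compound 2 is the nearest direct guide. Compound 4 is thus expected at 35000 nM, within 12000 nM to 100000 nM, which amounts to an estimated at least 2.8-fold lower number from compound 3 to compound 4 (0.45 log units; beyond the scatter).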

Compound 4, half-maximal inhibitory concentration: 25000 nM
For compound 4 the middle estimate is 1.4-fold (0.15 log units) above the measured one, within the range that was stated.
By their numbers in this assay, from the lowest: compounds 4, 1 and 2 (each within the scatter of the next). At a limit, above all of these: compound 3.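

In this assay, 3-hydroxyphenyl in place of ((4-hydroxyphenyl)carbamoyl)amino on the amide-type nitrogen gives an at least 4.0-fold lower number from compound 3 to compound 4 (0.60 log units; beyond the scatter), so a hydroxyphenyl group set directly on that nitrogen keeps a measurable number with the hydroxy in a second place on the ring. The ring pattern itself does not separate the compounds: 3-hydroxyphenyl in place of 4-hydroxyphenyl gives a 1.4-fold lower number from compound 2 to compound 4 (0.13 log units; within the scatter), and in place of 4-fluorophenyl it gives a 1.0-fold lower number from compound 1 to compound 4 (0.02 log units; within the scatter). The reading for compound 3 is a limit of the assay and not a number: the limit of > 100000 nM in this assay, at which 1 of the 4 values shown sits.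

Open, on these data alone, is whether an amine or a carboxylic acid on the phenyl ring, or a longer chain on the shared core, would move the number beyond the scatter. As far as these compounds go, how these steps carry over to other cell lines also stays open.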